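Compound 2 and the step to an ethyl analogue

The source may report more compounds than this note shows. Statements on the series, on what has been measured and on what is new or still open speak of the compounds shown alone.

compound 1 `Cc1ccc(C2=NN(c3ccc(S(C)(=O)=O)cc3)C(=O)CC2)cc1` gives 520 nM
compound 2 `Cc1cc(O)ccc1C1=NN(c2ccc(S(C)(=O)=O)cc2)C(=O)CC1` gives 6200 nM

In a functional assay on A549 cells (Homo sapiens) for inhibition, read by sulforhodamine B assay, with a stated time of 48 h (a higher number here means a weaker inhibitor of growth, a lower number a stronger inhibitor of growth), compound 2 at 6200 nM holds the higher of the two numbers, so it is the weaker inhibitor of growth of the pair. The change leading to compound 3 `CCc1ccc(C2=NN(c3ccc(S(C)(=O)=O)cc3)C(=O)CC2)cc1` is counted as 4-ethylphenyl in place of 4-hydroxy-2-methylphenyl on a carbon with a double bond to nitrogen and amounts to 4-ethylphenyl in place of 4-hydroxy-2-methylphenyl on a carbon with a double bond to nitrogen. Among the compounds with values here, one measured step bears on it: a 12-fold higher number from compound 1 to compound 2 (1.08 log units; beyond the scatter) for 4-hydroxy-2-methylphenyl in place of 4-methylphenyl, a large step beyond the scatter. Compound 3 gives up that same group, so a step of similar size in the opposite direction, towards a lower number, is expected. This assumes that 4-ethylphenyl compares with the 4-methylphenyl of compound 1, and no measurement here tests that. The expected step is a 10-fold lower number from compound 2 to compound 3 (1.01 log units; beyond the scatter) and would lie beyond the scatter. Compound 3 is estimated at 600 nM with an expected range from 200 nM to 1800 nM in this read-out.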

Compound 3, concentration for 50% growth inhibition: 910 nM
Compound 3: the middle estimate sits 1.5-fold (0.18 log units) below what was measured; the measured number falls inside the stated range.
By their numbers in this assay, from the lowest: compounds 1 and 3 (each within the scatter of the next); then compound 2.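

In this assay, the carbon with a double bond to nitrogen now has a third measured aromatic group, and 4-ethylphenyl in place of 4-hydroxy-2-methylphenyl gives a 6.8-fold lower number from compound 2 to compound 3 (0.83 log units; beyond the scatter) as a modest step, so the high number of compound 2 is not shared by compound 3. Methyl in place of hydrogen on the saturated chain carbon bound to an aromatic carbon gives a 1.8-fold higher number from compound 1 to compound 3 (0.24 log units; within the scatter) and so shows that this position takes 4-ethylphenyl and 4-methylphenyl with no difference that can be told from the scatter. No experimental evidence is available here to explain either step.

The compounds shown leave open which part of 4-hydroxy-2-methylphenyl goes with the higher number of compound 2, the hydroxy group or the added methyl, as the two appear only together. They also leave open how far this position stays tolerant, for instance with a longer chain such as propyl, or with an amine or a carboxylic acid on the same phenyl ring.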